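A few compounds are considered here, and "the series" means these few. Any claim that something is new, unique, unknown or untested is made for them only; others in the source may bear on it.

Measured so far in a physicochemical assay for solubility; a higher number here means a more soluble compound, a lower number a less soluble compound
compound 1 `O=C1OCCN1c1cc(C(F)(F)F)ccc1[C@H]1CCOc2cc(S(=O)(=O)Nc3nccs3)ccc21` gives 295000 nM
compound 2 `Cn1nccc1-c1cc(C(F)(F)F)ccc1[C@@H]1CCOc2cc(S(=O)(=O)Nc3nccs3)ccc21` gives 65000 nM

Compound 1 holds the higher of the two numbers in this assay and compound 2 sits lower, by a gap beyond the usual scatter. Among the measured compounds shown here, no two measured compounds differ in one place only, so the series offers no measured step to gauge a single change.

Compound 3 `O=C1COCCN1c1cc(C(F)(F)F)ccc1[C@H]1CCOc2cc(S(=O)(=O)Nc3nccs3)ccc21` has not yet been measured. It keeps the core of compound 1 and carries one change, described as 3-oxomorpholin-4-yl in place of 2-oxo-1,3-oxazolidin-3-yl on an aromatic carbon in the counted comparison. The change sits on an aromatic carbon of a six-membered aromatic ring of carbon only, meta to a trifluoromethyl group.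

Expected in this assay is no step beyond the scatter, with a slight lean towards a lower number. That expectation rests on compound 1 at 295000 nM as the only close anchor, and its uncertainty is wide. The estimated move is a 1.2-fold lower number from compound 1 to compound 3 (0.07 log units; within the scatter) in this reading. For compound 3 the estimated value is 250000 nM with an expected range of 110000 nM to 600000 nM in this measurement.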

Compound 3, solubility: 695000 nM
Estimate against measurement, compound 3: 2.8-fold (0.44 log units) below; measured number above the stated range.
By their numbers in this assay, from the lowest: compound 2; then compound 1; then compound 3.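

At the aromatic carbon ortho to a large group and meta to a trifluoromethyl group, this assay now has its first one-place step: 3-oxomorpholin-4-yl in place of 2-oxo-1,3-oxazolidin-3-yl gives a 2.4-fold higher number from compound 1 to compound 3 (0.37 log units; beyond the scatter), modest in size but beyond the scatter. The read-out at this position therefore responds to a swap from a five-membered to a six-membered non-aromatic ring, even though the hydrogen-bond donor and acceptor counts stay the same and neither group carries a net charge. Nothing measured here accounts for the move.

From the compounds shown here alone, with a single step at this position, it remains open whether the higher number goes with the six-membered ring in general or with 3-oxomorpholin-4-yl alone, and whether the ring carbonyl has any part in it. A morpholin-4-yl group without the carbonyl, a seven-membered ring or an open-chain amide on the same aromatic carbon would test those readings, and a carboxylic acid or an amine there would show how far the number can move from the values of compound 1 and compound 3.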